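A few compounds are considered here, and "the series" means these few. Any claim that something is new, unique, unknown or untested is made for them only; others in the source may bear on it.

In an ADME assay on L02 cells (Homo sapiens) for inhibition, read by CCK-8 assay, with a stated time of 48 h (on this read-out lower numbers stand for stronger inhibition of growth and higher numbers for weaker inhibition of growth), compound 1 (`Cc1ccccc1Nc1nc(Nc2ccccc2)ncc1Cl`) gives > 100000 nM, a limit and not a number. Compound 2 (`Cc1ccc(Nc2ncc(Cl)c(Nc3ccccc3C)n2)cc1`) gives > 100000 nM, likewise a limit. Compound 2 therefore stands at the limit of > 100000 nM in this assay, at which 2 of the 2 values shown sit. Among the measured compounds shown here, the only measured step, a step that the two limits leave unreadable from compound 1 to compound 2, gives no usable size. Compound 3 (`Cc1ccccc1Nc1nc(Nc2ccc(N3CCN(C)CC3)cc2)ncc1Cl`) has 4-methylpiperazin-1-yl in place of methyl on an aromatic carbon, para to a large group: 4-methylpiperazin-1-yl in place of methyl on an aromatic carbon. No measured step sizes this change, so a modest move toward stronger inhibition in this assay is only a tentative expectation, and another limit remains possible. The expected step is an at least 2.5-fold lower number from compound 2 to compound 3 (0.39 log units; beyond the scatter). For compound 3 the estimated value is 40000 nM, with an expected range of 10000 nM to 100000 nM.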

Compound 3, concentration for 50% growth inhibition: 6510 nM
Estimate against measurement, compound 3: 6.1-fold (0.79 log units) above; the measured number lies below the stated range.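

In this assay, 4-methylpiperazin-1-yl at this place, para to a large group, brings the series off its limit, with an at least 15-fold lower number from compound 2 to compound 3 (1.18 log units; beyond the scatter) and an at least 15-fold lower number from compound 1 to compound 3 (1.18 log units; beyond the scatter) as the readable steps. Both steps start from a limit, so their full size cannot be read, and the step between the two compounds at the limit cannot be read either. Only compound 3 gives a number, while the other two compounds sit at a limit: the limit of > 100000 nM in this assay, at which 2 of the 3 values shown sit.

As far as these compounds go, it remains open whether the ring or its terminal methyl carries the change. A morpholine, a piperidine or a dimethylamino group at this place would separate these.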